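Amide aryl variation on the shared core

The source may hold more compounds than are shown below. What is called first, only, known or untested is meant among the compounds shown, and "the series" means these compounds.

Compound 1 `O=C(Nc1cccc(-c2oc3cc(-c4ccc(F)cc4)ccc3c(=O)c2O)c1)c1ccc(C(F)(F)F)cc1` carries a 4-(trifluoromethyl)phenyl on the carbonyl carbon of the amide. Among the measured compounds shown here, in a functional assay on HeLa cells (Homo sapiens) for antiproliferative activity, read by CCK-8 assay, with a stated time of 72 h (a higher number here means a weaker inhibitor, a lower number a stronger inhibitor), compound 1 gives 17400 nM, the highest of the three numbers measured so far. Compound 2 `O=C(Nc1cccc(-c2oc3cc(-c4ccc(F)cc4)ccc3c(=O)c2O)c1)c1cc(F)cc(F)c1` gives 3380 nM in this assay, and compound 3 `O=C(Nc1cccc(-c2oc3cc(-c4ccc(F)cc4)ccc3c(=O)c2O)c1)c1ccc([N+](=O)[O-])cc1` gives 12300 nM. The step of a 5.1-fold lower number from compound 1 to compound 2 (0.71 log units; beyond the scatter) is modest but beyond the scatter; the step of a 1.4-fold lower number from compound 1 to compound 3 (0.15 log units; within the scatter) stays within it, and the step of a 3.6-fold higher number from compound 2 to compound 3 (0.56 log units; beyond the scatter) is again modest.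

Compound 4 `O=C(Nc1cccc(-c2oc3cc(-c4ccc(F)cc4)ccc3c(=O)c2O)c1)c1ccc(-c2ccccc2)cc1` is not yet measured. It differs from compound 1 as follows: phenyl in place of trifluoromethyl on an aromatic carbon. For the measured compounds named here, no measured step exchanges trifluoromethyl for phenyl, so none bears on it directly. Going by the values given here, the closest comparison is the exchange of substituent on an aromatic carbon, a 1.4-fold lower number from compound 1 to compound 3 (0.15 log units; within the scatter), which changed nothing beyond the scatter; the move to 3,5-difluorophenyl, a 5.1-fold lower number from compound 1 to compound 2 (0.71 log units; beyond the scatter), was the only step that did. A step within or near the scatter is therefore expected in this assay, with no firm direction and a wide range. For compound 4 the expected value in this assay is 13000 nM, between 3500 nM and 45000 nM. The expected step is a 1.3-fold lower number from compound 1 to compound 4 (0.13 log units; within the scatter), which would sit within the scatter.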

Compound 4, half-maximal inhibitory concentration: > 100000 nM
Compound 4 ended at the assay's limit (the forecaster's own chance of this, stated with the estimate: 5%); at least 7.6-fold (0.88 log units) between middle value and limit.
By their numbers in this assay, from the lowest: compound 2; then compounds 3 and 1 (each within the scatter of the next). At a limit, above all of these: compound 4.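

In this assay compound 4 gives no number, only a limit: the limit of > 100000 nM in this assay, at which 1 of the 4 values shown sits.

The exchange of trifluoromethyl for nitro on this aromatic carbon, para to a large group, stayed within the scatter as a 1.4-fold lower number from compound 1 to compound 3 (0.15 log units; within the scatter), so the position looked indifferent to its substituent, but phenyl in the same place gives an at least 5.7-fold higher number from compound 1 to compound 4 (0.75 log units; beyond the scatter) and an at least 8.1-fold higher number from compound 3 to compound 4 (0.91 log units; beyond the scatter), which shows that the group at this position can matter a good deal in this series. Among the compounds shown here, measured against the 3,5-difluorophenyl amide, the move to 4-phenylphenyl gives an at least 29-fold higher number from compound 2 to compound 4 (1.47 log units; beyond the scatter), the only step so far rated large, and its true extent stays unknown while one end of it is a limit.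

On these data alone, the actual value of compound 4 remains open, and so does whether any group carrying a ring at this place behaves like phenyl, for instance cyclohexyl or a pyridine ring. Also open, as far as these compounds go, is what an amine, a carboxylic acid or a methoxy group would do on the same aromatic carbon, where only trifluoromethyl, nitro and phenyl stand so far.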